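Cytotoxicity in HT-29 cells across a small series

The source may hold more compounds than are shown below. What is called first, only, known or untested is meant among the compounds shown, and "the series" means these compounds.

Measured compounds:
Compound 1 `C=CC(=O)Nc1cc(Nc2ncc3ncn(-c4ccc(C(C)C)cc4)c3n2)c(OC)cc1N1CCN(C)CC1`, 7690 nM
Compound 2 `C=CC(=O)Nc1cc(Nc2ncc3ncn(-c4ccc(I)cc4)c3n2)c(OC)cc1N1CCN(C)CC1`, 20700 nM
Compound 3 `C=CC(=O)Nc1cc(Nc2ncc3[nH]c(=O)n(-c4ccc(C(C)C)cc4)c3n2)c(OC)cc1N1CCN(C)CC1`, 14300 nM

The series was tested in an ADME assay on HT-29 cells (Homo sapiens) for cytotoxicity, read by MTT assay, with a stated time of 72 h; on this read-out lower numbers stand for stronger inhibition and higher numbers for weaker inhibition. Compound 1 gives 7690 nM. Compound 2 differs from it by iodo in place of isopropyl on an aromatic carbon, and this change brings a 2.7-fold higher number from compound 1 to compound 2 (0.43 log units; beyond the scatter). Compound 3 gives 14300 nM in this assay; it carries a different core from compound 1, and the difference between the two cores is not broken down here. The values of compound 3 and compound 2 lie within the usual scatter of each other, as do those of compound 3 and compound 1.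

Compound 4 `C=CC(=O)Nc1cc(Nc2ncc3[nH]c(=O)n(-c4ccc(I)cc4)c3n2)c(OC)cc1N1CCN(C)CC1` has not yet been measured in this assay. It differs from compound 3 by iodo in place of isopropyl on an aromatic carbon, the same kind of change as that from compound 1 to compound 2. Carrying over the earlier step, compound 4 is expected to show a 2.5-fold higher number from compound 3 to compound 4 (0.40 log units; beyond the scatter), which rests on the step of a 2.7-fold higher number from compound 1 to compound 2 (0.43 log units; beyond the scatter) applied to the value of compound 3. Compound 4 is therefore estimated at 36000 nM, within a range from 15000 nM to 90000 nM.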

Compound 4, half-maximal inhibitory concentration: 39300 nM
Compound 4: the middle estimate sits 1.1-fold (0.04 log units) below what was measured, within the range that was stated.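

In this assay, iodo in place of isopropyl on the second core brings a 2.7-fold higher number from compound 3 to compound 4 (0.44 log units; beyond the scatter), and set beside the step on the first core it is of the same size: the same change on two cores in this assay, a 2.7-fold higher number (0.43 log units; beyond the scatter) from compound 1 to compound 2 and a 2.7-fold higher number (0.44 log units; beyond the scatter) from compound 3 to compound 4, 1.0-fold (0.01 log units) apart, within the scatter of two such steps This shows that, for these two matched pairs, the change carried over from one core to the other with its size unaltered, so the difference between the cores did not alter the step. For the compounds shown here, it rests on only two pairs, one exchange of groups and one cell line, so it does not establish a general rule for other cores, nor does it explain why the step has this size.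

The compounds shown leave open whether other groups on the same aromatic carbon, such as bromo, an amine, a carboxylic acid or a longer chain, would also give steps that carry over between the two cores. They also leave open whether the iodo for isopropyl step would keep its size on a third core or in another cell line.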